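Chain-end carboxylic acid on the butyl arm of compound 1

A few compounds are considered here, and "the series" means these few. Any claim that something is new, unique, unknown or untested is made for them only; others in the source may bear on it.

Going by the values given here, compound 1 `CCCCn1nc(-c2ccccc2)c(-c2ccccc2)cc1=O` gives 176000 nM in an assay on microsomes from liver for inhibition of sterol O-acyltransferase 1 (Rattus norvegicus) (a lower number here means a stronger inhibitor, a higher number a weaker inhibitor), the only plain number in the set. Compound 2 `O=c1cc(-c2ccccc2)c(-c2ccccc2)nn1C1CCCCC1` reaches only a limit in this assay, > 300000 nM. The step of an at least 1.7-fold higher number from compound 1 to compound 2 (0.23 log units; that floor lies within the scatter) rests on that limit (the limit of > 300000 nM in this assay, at which 1 of the 2 values shown sits), so its floor says little. Compound 3 `O=C(O)CCCCCCn1nc(-c2ccccc2)c(-c2ccccc2)cc1=O` differs from compound 1 by 2-carboxyethyl in place of hydrogen on a saturated chain carbon, four bonds along the chain from an aromatic nitrogen. No measured step alters the chain in this way; the one step shown swaps the whole chain for a ring, so it bears only loosely on this change. The number for compound 3 is therefore expected somewhat higher, the step of a 1.4-fold higher number from compound 1 to compound 3 (0.15 log units; within the scatter). The estimate for compound 3 is 250000 nM, between 80000 nM and 800000 nM.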

Compound 3, half-maximal inhibitory concentration: > 300000 nM
Compound 3: a limit, no number; the forecaster's own chance of this, stated with the estimate: 45%; middle value at least 1.2-fold (0.07 log units) away from the limit.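

Compound 3 reaches only a limit in this assay, > 300000 nM. Placing 2-carboxyethyl on the saturated chain carbon gives an at least 1.7-fold higher number from compound 1 to compound 3 (0.23 log units; that floor lies within the scatter), so the chain-end carboxylic acid shows no sign of stronger inhibition, and the true size of the step stays unknown. The series now rests largely on a ceiling: the limit of > 300000 nM in this assay, at which 2 of the 3 values shown sit.

The step between the two limits cannot be read. Still open, on these data alone, is whether an amine or a methyl ester at the chain end, or a shorter acid chain, would give a plain number.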